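The source may report more compounds than this note shows. Statements on the series, on what has been measured and on what is new or still open speak of the compounds shown alone.

Measured compounds:
compound 1 `CCOC(=O)c1sc2ccc(NCc3c[nH]cn3)cc2c1NC(=O)c1ccc(OC)cc1` — 12900 nM
compound 2 `CCOC(=O)c1sc2ccc(NCc3c[nH]cn3)cc2c1NC(=O)c1ccc(C)cc1` — 11700 nM

Going by the values given here, in a functional assay on HeLa cells (Homo sapiens) for antiproliferative activity, read by MTT assay, with a stated time of 48 h (on this read-out lower numbers stand for stronger inhibition of growth and higher numbers for weaker inhibition of growth), compound 2 gives 11700 nM, and compound 1 gives 12900 nM; the only measured step, a 1.1-fold lower number from compound 1 to compound 2 (0.04 log units; within the scatter), is within the scatter, so compound 2 stands alongside compound 1 rather than apart from it. Compound 3 `CCOC(=O)c1sc2ccc(N)cc2c1NC(=O)c1ccc(C)cc1` differs from compound 2 by hydrogen in place of (1H-imidazol-4-yl)methyl on a nitrogen on an aromatic ring. That step changes the aryl amine, which the measured step does not touch, so nothing measured bears directly on it. The expected step is a 1.9-fold higher number from compound 2 to compound 3 (0.27 log units; within the scatter), a modest shift toward weaker inhibition, with wide uncertainty. Compound 3 is therefore expected to give 22000 nM, within 6000 nM to 80000 nM.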

Compound 3, concentration for 50% growth inhibition: 24400 nM
Compound 3: the middle estimate sits 1.1-fold (0.04 log units) below what was measured; measured number inside the range.
By their numbers in this assay, from the lowest: compounds 2, 1 and 3 (each within the scatter of the next, the first and the last beyond it).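

In this assay, going by these compounds alone, this is the first change at the nitrogen on the aromatic ring, since compound 1 and compound 2 differ only in methoxy against methyl. Replacing (1H-imidazol-4-yl)methyl with hydrogen gives a 2.1-fold higher number from compound 2 to compound 3 (0.32 log units; beyond the scatter), so this group adds a modest amount to growth inhibition, and the plain amino compound still registers in the same assay. No available data explain this step.

As far as these compounds go, it remains open whether the ring itself matters or any group on that nitrogen would do. A benzyl or a plain methyl group there would help separate these possibilities.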